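A few compounds are considered here, and "the series" means these few. Any claim that something is new, unique, unknown or untested is made for them only; others in the source may bear on it.

Compound 3 `O=C1COC(c2ccc(/N=C/c3cccc(Cl)c3)cc2)=NN1` stands second highest of the three numbers in an assay on cells for inhibition of Amine oxidase [flavin-containing] B (Homo sapiens), read by Amplex Red, with a stated time of 30 min (a lower number here means a stronger inhibitor, a higher number a weaker inhibitor), where compound 3 gives 257 nM. Its nearest neighbour is compound 1 `O=C1COC(c2ccc(/N=N/c3ccc(Cl)cc3)cc2)=NN1`, which in this assay gives 392 nM, a gap within the scatter. The furthest is compound 2 `Cc1cccc(/N=N/c2ccc(C3=NNC(=O)CO3)cc2)c1`, which in this assay gives 25 nM, a gap beyond the scatter.

Compound 4 `Cc1cccc(/C=N/c2ccc(C3=NNC(=O)CO3)cc2)c1` differs from compound 3 by methyl in place of chloro on an aromatic carbon. For the measured compounds named here, no measured step repeats this change exactly. Going by the values given here, the one step that bears on it is a 16-fold lower number from compound 1 to compound 2 (1.20 log units; beyond the scatter), which exchanges group and position together on the double-bonded nitrogen, whereas the change to compound 4 keeps the position and only swaps chloro for methyl. Among the compounds with values here, compound 2, which carries the 3-methylphenyl, has the lowest number of the three, and that step was large, so a lower number is expected for compound 4; a smaller step than the one from compound 1 to compound 2 seems prudent, as only part of that change recurs here.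

Compound 4 is expected to give in this assay about 60 nM, between 20 nM and 200 nM, an estimated step of a 4.3-fold lower number from compound 3 to compound 4 (0.63 log units; beyond the scatter).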

Compound 4, half-maximal inhibitory concentration: 1270 nM
The estimate for compound 4 lay 21-fold (1.33 log units) below the measured number; measured number above the stated range.
By their numbers in this assay, from the lowest: compound 2; then compounds 3 and 1 (each within the scatter of the next); then compound 4.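

In this assay, the step of a 4.9-fold higher number from compound 3 to compound 4 (0.69 log units; beyond the scatter) shows that methyl in place of chloro on this aromatic carbon, meta to a large group, raises the number, the opposite direction to a 16-fold lower number from compound 1 to compound 2 (1.20 log units; beyond the scatter), where group and position changed together. The 3-methylphenyl group therefore does not bring a low number on its own: compound 2 gives 25 nM, whereas compound 4 gives 1270 nM, with the link to that ring differing between them. No measurement is available that accounts for this step.

Still open, going by these compounds, is how a methoxy group or an amine would read in place of the chloro on the 3-chlorophenyl. On these data alone, it is also open whether chloro and methyl keep this order on the link carried by compound 2.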